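Emax notes on a linker-reversed benzyloxy analogue

The compounds below may be only part of what the source reports. "The series", "measured", "known", "first", "only" and "open" are said of these compounds alone.

Measured so far:
compound 1 `O=C1c2cc(COc3ccccc3)nn2CCN1c1ccc(F)cc1` — 79%
compound 2 `O=C1c2cc(COc3ccncc3)nn2CCN1c1ccc(F)cc1` — 69%

Compound 1 `O=C1c2cc(COc3ccccc3)nn2CCN1c1ccc(F)cc1` and compound 2 `O=C1c2cc(COc3ccncc3)nn2CCN1c1ccc(F)cc1` were run in a functional assay on HEK293 cells for positive allosteric modulation of metabotropic glutamate receptor 5 (Homo sapiens), read by calcium flux; a higher number here means a larger maximal response, a lower number a smaller maximal response. Compound 1 gives 79% and compound 2 gives 69%. Within the data shown here, the one step between them, a number 10 percentage points lower from compound 1 to compound 2 (within the scatter), sits within the scatter, so the two numbers cannot be ordered; compound 2 has the lower of the two numbers but is not to be called the weaker.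

Compound 3 `O=C1c2cc(OCc3ccccc3)nn2CCN1c1ccc(F)cc1` has not been measured. Against compound 2 the change is benzyloxy in place of ((pyridin-4-yl)oxy)methyl on an aromatic carbon. Among the measured compounds shown here, the only measured step that touches this change is the ring swap in a number 10 percentage points lower from compound 1 to compound 2 (within the scatter), which stayed within the scatter; the reversal of the oxygen and methylene within the side chain has no measured counterpart, so nothing is known about its effect on the maximal response. The expectation for compound 3 in this assay therefore rests on the ring swap alone and amounts to a number 5 percentage points higher from compound 2 to compound 3 (within the scatter), a step expected to stay within the scatter. The estimated value for compound 3 is 74%, with a range of 50% to 95% to cover the unmeasured linker reversal.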

Compound 3, largest response reached (Emax), in percent of the reference or control that the assay uses: 54%
Beside the measured number, compound 3's estimate is 20 percentage points above it; measured number inside the range.
By their numbers in this assay, from the lowest: compound 3; then compounds 2 and 1 (each within the scatter of the next).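

In this assay, among these compounds, the side chain on this aromatic carbon of the five-membered ring can shift the maximal response beyond the scatter, which the ring swap between the earlier compounds did not show. Phenoxymethyl and benzyloxy share the carbon-only ring and differ in the order of the oxygen and the methylene, and replacing the former with the latter gives a number 25 percentage points lower from compound 1 to compound 3 (beyond the scatter) in this series, so the order of these two links matters here even with the ring unchanged. Benzyloxy in place of ((pyridin-4-yl)oxy)methyl gives a number 15 percentage points lower from compound 2 to compound 3 (beyond the scatter), but that step changes the ring and the order together, so it cannot assign the drop to either one, and nothing available bears on the origin of either step.

As far as these compounds go, whether the ring swap would stay as small with the reversed order remains open, and pyridin-4-ylmethoxy at this position would address that directly. Also open, from the compounds shown here alone, is whether the drop is tied to the oxygen next to the five-membered ring or to the chain as a whole, a question that benzylamino or a longer chain such as 2-phenylethoxy could help separate.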